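Removing the 4-fluorophenyl group from compound 3

A few compounds are considered here, and "the series" means these few. Any claim that something is new, unique, unknown or untested is made for them only; others in the source may bear on it.

Values in a physicochemical assay (a lower number here means a stronger inhibitor, a higher number a weaker inhibitor), are as follows
compound 1 `COc1cc(C=C(C(=O)/C=C/c2ccc(N(C)C)cc2)C(=O)/C=C/c2ccc(N(C)C)cc2)ccc1O` gives 45 ug/mL
compound 2 `COc1ccc(-n2nc(/C=C/c3ccc(N(C)C)cc3)cc2/C=C/c2ccc(N(C)C)cc2)cc1` gives 79.6 ug/mL
compound 3 `CN(C)c1ccc(/C=C/c2cc(/C=C/c3ccc(N(C)C)cc3)n(-c3ccc(F)cc3)n2)cc1` gives 89.1 ug/mL

On these numbers compound 3 at 89.1 ug/mL stands within the scatter of both compound 2 and compound 1. Compound 4 `CN(C)c1ccc(/C=C/c2cc(/C=C/c3ccc(N(C)C)cc3)[nH]n2)cc1` carries hydrogen in place of 4-fluorophenyl on an aromatic nitrogen, with hydrogen in place of 4-fluorophenyl on an aromatic nitrogen as the counted difference. For the measured compounds named here, the only measured step, a 1.1-fold higher number from compound 2 to compound 3 (0.05 log units; within the scatter) for fluoro in place of methoxy on an aromatic carbon, stays within the scatter, yet no measured step removes the whole group. A step beyond the scatter in this assay is therefore not expected, though confidence is low. The estimate means a 1.3-fold lower number from compound 3 to compound 4 (0.10 log units; within the scatter) as the expected step. Compound 4 is estimated at 70 ug/mL with an expected range of 30 ug/mL to 150 ug/mL for now.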

Compound 4, half-maximal inhibitory concentration: 50.8 ug/mL
Beside the measured number, compound 4's estimate is 1.4-fold (0.14 log units) above it; low and high end bracket the measured number.
By their numbers in this assay, from the lowest: compounds 1, 4, 2 and 3 (each within the scatter of the next).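

In this assay, hydrogen in place of 4-fluorophenyl on the aromatic nitrogen gives a 1.8-fold lower number from compound 3 to compound 4 (0.24 log units; within the scatter) and hydrogen in place of 4-methoxyphenyl there gives a 1.6-fold lower number from compound 2 to compound 4 (0.20 log units; within the scatter) as the second step. Earlier, only a swap on the aromatic ring of that group had been compared; now the whole group goes, and both steps stay within the scatter. So, among these compounds, the number does not depend on an aromatic ring at this nitrogen. No measurement shown here accounts for these steps. On these data alone, whether a methyl group, a longer chain or a carboxylic acid on this nitrogen would give a step beyond the scatter remains open.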